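A few compounds are considered here, and "the series" means these few. Any claim that something is new, unique, unknown or untested is made for them only; others in the source may bear on it.

Compound 1 `Cc1ccc2c(O)cc(-c3cccc(Cl)c3)nc2n1` and compound 3 `Cc1cc(C)c2c(O)cc(-c3cccc(Cl)c3)nc2n1` share one core; compound 2 `Oc1cc(-c2ccc3ccccc3c2)nc2ncccc12` is built on another core, and the difference between the two cores is not broken down here. In a functional assay on PC-3 cells (Homo sapiens) for antiproliferative activity (a lower number here means a stronger inhibitor of growth, a higher number a weaker inhibitor of growth), compound 1 gives > 100000 nM, which is a limit of the assay and not a number (the limit of > 100000 nM in this assay, at which 1 of the 3 values shown sits). Compound 3 gives 27.5 nM in this assay. The change separating the two is methyl in place of hydrogen on an aromatic carbon and the resulting step is an at least 3600-fold lower number from compound 1 to compound 3 (3.56 log units; beyond the scatter). Compound 2 gives 10500 nM in this assay. Compound 4 `Cc1cnc2nc(-c3ccc4ccccc4c3)cc(O)c2c1`, not yet measured, differs from compound 2 by methyl in place of hydrogen on an aromatic carbon. Among the measured compounds shown here, this is the same kind of change as the one from compound 1 to compound 3, not the same change: in compound 3 the methyl sits ortho to a fused ring, meta to a methyl group and opposite the ring nitrogen, whereas in compound 4 it sits two atoms from the ring nitrogen, meta and para to a fused ring. Resting on the measured step of an at least 3600-fold lower number from compound 1 to compound 3 (3.56 log units; beyond the scatter) at that other place, the step expected here is smaller, estimated at a 4.2-fold lower number from compound 2 to compound 4 (0.62 log units; beyond the scatter). Compound 4 is expected at 2500 nM, with an estimated range from 300 nM to 12000 nM.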

Compound 4, concentration for 50% growth inhibition: 407 nM
Estimate against measurement, compound 4: 6.1-fold (0.79 log units) above; the measured number falls inside the stated range.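

In this assay, methyl in place of hydrogen on an aromatic carbon also gives a 26-fold lower number from compound 2 to compound 4 (1.41 log units; beyond the scatter), so in these two pairs the direction of the change carries from one core to the other, but its size does not: the same change on two cores in this assay, an at least 3600-fold lower number (3.56 log units; beyond the scatter) from compound 1 to compound 3 and a 26-fold lower number (1.41 log units; beyond the scatter) from compound 2 to compound 4, at least 140-fold (2.14 log units) apart, beyond the scatter of two such steps

This does not show what sets the size of the step, as the two pairs differ in core and also in where the methyl sits, and in compound 4 it sits two atoms from the ring nitrogen. Compound 1 gives > 100000 nM, which is a limit of the assay and not a number.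

The compounds shown leave open how much of the gap between the two steps belongs to the core and how much to the place of the methyl. Also open, from the compounds shown here alone, is whether a longer chain such as ethyl, or an amine, at the place taken by the methyl in compound 4 would move the number in the same direction.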